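Dichlorophenyl for difluorophenyl on the triazole nitrogen

A few compounds are considered here, and "the series" means these few. Any claim that something is new, unique, unknown or untested is made for them only; others in the source may bear on it.

Compound 1, `Cc1ccccc1-n1nncc1CN1C(=O)C2(C(C#N)=C(N)Oc3c(N)cc4nc5ccccc5nc4c32)c2ccccc21`, in an ADME assay on L02 cells (Homo sapiens) for antiproliferative activity, read by MTT assay, with a stated time of 48 h (a lower number here means a stronger inhibitor, a higher number a weaker inhibitor), gives > 50000 nM, which is a limit of the assay and not a number.
Compound 2, `N#CC1=C(N)Oc2c(N)cc3nc4ccccc4nc3c2C12C(=O)N(Cc1cnnn1-c1c(F)cccc1F)c1ccccc12`, in this assay gives > 50000 nM, which is likewise a limit of the assay.

In this assay, among the measured compounds shown here, compound 2 therefore stands only at a limit, and the one further value shown is a limit as well. The step that the two limits leave unreadable from compound 1 to compound 2 cannot be read, because of the limit of > 50000 nM in this assay, at which 2 of the 2 values shown sit.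

Compound 3, `N#CC1=C(N)Oc2c(N)cc3nc4ccccc4nc3c2C12C(=O)N(Cc1cnnn1-c1ccc(Cl)cc1Cl)c1ccccc12`, is the next member. It differs from compound 2 by 2,4-dichlorophenyl in place of 2,6-difluorophenyl on an aromatic nitrogen. For the measured compounds named here, the only measured step that touches the same place is a step that the two limits leave unreadable from compound 1 to compound 2, an exchange of one aryl group for another on that aromatic nitrogen, and its size is not readable. No direction can be drawn from it, and no step beyond the scatter is expected in this assay for the change from compound 2 to compound 3.

Compound 3 is accordingly expected to remain at the limit, with an estimate of 50000 nM and a range from 20000 nM to 120000 nM. This estimate means an expected step of a number no higher from compound 2 to compound 3 (the limit leaves the size open).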

Compound 3, half-maximal inhibitory concentration: > 50000 nM
Compound 3 was reported as a limit; the forecaster's own chance of this, stated with the estimate: 85%; the middle value lies on the limit itself.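

In this assay compound 3 gives > 50000 nM which is a limit of the assay and not a number. Among the compounds shown here, no step among compound 1, compound 2 and compound 3 can be read: the limit of > 50000 nM in this assay, at which 3 of the 3 values shown sit.

The compounds shown leave open how far each lies from that limit, and whether exchanging one aryl group for another on that aromatic nitrogen changes the read-out at all.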